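A few compounds are considered here, and "the series" means these few. Any claim that something is new, unique, unknown or untested is made for them only; others in the source may bear on it.

In a functional assay on SW-620 cells (Homo sapiens) for cytotoxicity, read by MTT assay, with a stated time of 72 h (on this read-out lower numbers stand for stronger inhibition and higher numbers for weaker inhibition), two compounds on a shared core have been measured so far. Compound 1 (`COc1ccc(/C=C2\CCC/C(=C\c3ccc(OC)c(OC)c3)C2=O)cc1`) gives 6600 nM, and compound 2 (`COc1ccc(/C=C2\CCC/C(=C\c3cccc(O)c3)C2=O)cc1OC`) gives 1900 nM, the lower of the two numbers. Among the compounds with values here, the only measured step, a 3.5-fold lower number from compound 1 to compound 2 (0.54 log units; beyond the scatter), is modest and came with 3-hydroxyphenyl in place of 4-methoxyphenyl. Compound 3 (`COc1ccc(/C=C2\CCC/C(=C\c3ccc(Cl)c(Cl)c3)C2=O)cc1OC`) changes the same place, on a double-bonded chain carbon bound to a double-bonded ring carbon, with 3,4-dichlorophenyl in place of 3-hydroxyphenyl on a double-bonded chain carbon bound to a double-bonded ring carbon. Within the data shown here, no measured compound carries chlorine, so that single step is the only guide. Compound 3 gives up the 3-hydroxyphenyl that came with a 3.5-fold lower number from compound 1 to compound 2 (0.54 log units; beyond the scatter), so part of that drop may be lost, and a small move toward a higher number is expected. The estimated change is a 1.6-fold higher number from compound 2 to compound 3 (0.20 log units; within the scatter). For compound 3 the expected value is 3000 nM, with an estimated range from 1000 nM to 9000 nM.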

Compound 3, half-maximal inhibitory concentration: 4000 nM
Estimate against measurement, compound 3: 1.3-fold (0.12 log units) below; the range from low to high includes it.
By their numbers in this assay, from the lowest: compound 2; then compounds 3 and 1 (each within the scatter of the next).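

At this position, on a double-bonded chain carbon bound to a double-bonded ring carbon, this assay now shows that 3,4-dichlorophenyl in place of 3-hydroxyphenyl gives a 2.1-fold higher number from compound 2 to compound 3 (0.32 log units; beyond the scatter), so the lower number of compound 2 does not carry over to this chlorine-bearing ring. Set against the 4-methoxyphenyl of compound 1, the same group gives a 1.7-fold lower number from compound 1 to compound 3 (0.22 log units; within the scatter), so compound 3 and compound 1 cannot be told apart, and of the three groups only 3-hydroxyphenyl stands apart, with its steps to both others beyond the scatter. Nothing at hand explains this difference.

The compounds shown leave open whether the lower number of compound 2 goes with the hydroxy group itself, and how a plain phenyl, or a phenyl bearing an amine or a carboxylic acid, would read in this assay. They also leave open whether this order holds in any other cell line.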